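The source may report more compounds than this note shows. Statements on the series, on what has been measured and on what is new or still open speak of the compounds shown alone.

Working notes, values in a functional assay on HeLa cells (Homo sapiens) for antiproliferative activity, read by MTT assay, with a stated time of 48 h; on this read-out higher numbers stand for weaker inhibition and lower numbers for stronger inhibition:
- compound 1 `Clc1ccc2[nH]c(-c3cn(-c4ccccc4)nc3-c3ccccc3)nc2c1` gives 3480 nM
- compound 2 `Fc1ccc(-c2nn(-c3ccccc3)cc2-c2nc3cc(Cl)ccc3[nH]2)cc1` gives 2770 nM
- compound 3 `Fc1ccc(-c2nn(-c3ccccc3)cc2-c2nc3cc(Cl)c(Cl)cc3[nH]2)cc1` gives 11600 nM
- compound 4 `O=C(OCc1ccccc1)c1ccc2[nH]c(-c3cn(-c4ccccc4)nc3-c3ccc(F)cc3)nc2c1` is not yet measured

Compound 2 shares the low end of these numbers with compound 1, as shown by a 1.3-fold lower number from compound 1 to compound 2 (0.10 log units; within the scatter). The change to consider is benzyloxycarbonyl in place of chloro on an aromatic carbon. That fluoro step lies elsewhere on the molecule and does not bear on it. The closest evidence is a 4.2-fold higher number from compound 2 to compound 3 (0.62 log units; beyond the scatter), a modest rise on adding chloro to the same ring. Within the data shown here, no measured step replaces the chloro itself, so only a modest rise in this assay is expected, with wide uncertainty. The expected change is a 1.8-fold higher number from compound 2 to compound 4 (0.26 log units; within the scatter). Compound 4 is estimated at 5000 nM, within a range of 1200 nM to 20000 nM.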

Compound 4, half-maximal inhibitory concentration: 23600 nM
Compound 4: the middle estimate sits 4.7-fold (0.67 log units) below what was measured; the measured number lies above the stated range.
By their numbers in this assay, from the lowest: compounds 2 and 1 (each within the scatter of the next); then compound 3; then compound 4.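

In this assay, among these compounds, the step of an 8.5-fold higher number from compound 2 to compound 4 (0.93 log units; beyond the scatter) is the first change of the chloro itself, and it shows that this position does not readily accept benzyloxycarbonyl. The step brings in a carbonyl, a second six-membered aromatic ring and more heavy atoms at once, so this single comparison cannot separate their contributions. No measurement here gives a reason for the rise.

Open, on these data alone, is whether a carboxylic acid or a methyl ester at this position would stay closer to compound 2. Also open, as far as these compounds go, is whether the benzyl part or the carbonyl accounts for the change.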